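From compound 3 to compound 4: a series at its limit

This account rests on a few compounds, and the source may have more. Where it says the series, first, only, none or still open, it means among the compounds named here.

Compound 1 `Cc1cc(C)c(S(=O)(=O)N2CCC(N3CCC(C)CC3)CC2)c(C)c1` gives > 5000 nM
Compound 2 `Cc1ccc(C2CCN(S(=O)(=O)c3c(C)cc(C)cc3C)CC2)cc1` gives > 5000 nM
Compound 3 `Cc1cc(C)c(S(=O)(=O)N2CCC(N3CC(C)CC(C)C3)CC2)c(C)c1` gives > 5000 nM

In an ADME assay on HCT-116 cells (Homo sapiens) for cytotoxicity, read by CellTiter-Glo, with a stated time of 72 h (on this read-out higher numbers stand for weaker inhibition and lower numbers for stronger inhibition), compound 3 gives > 5000 nM, which is a limit of the assay and not a number. Compound 1 and compound 2 stand at that same limit, so the whole evidence so far is the limit of > 5000 nM in this assay, at which 3 of the 3 values shown sit.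

Compound 4 `Cc1cc(C)c(S(=O)(=O)N2CCC(N3CCC(O)CC3)CC2)c(C)c1` keeps the core of compound 3 and changes one group: 4-hydroxypiperidin-1-yl in place of 3,5-dimethylpiperidin-1-yl on a saturated ring carbon. A 4-hydroxypiperidin-1-yl group thus takes the place of the 3,5-dimethylpiperidin-1-yl group on the saturated ring carbon.

Three measured steps changed a group at this place: a step that the two limits leave unreadable from compound 1 to compound 2, a step that the two limits leave unreadable from compound 1 to compound 3 and a step that the two limits leave unreadable from compound 2 to compound 3. None of them has a readable size, so they offer no measured size or direction to carry over. All three compounds stayed at the limit, so compound 4 is expected to be reported as a limit too.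

The estimated change is a step that the limit leaves unreadable from compound 3 to compound 4, with no firm direction expected.

For compound 4 the estimate is 8000 nM, with an expected range from 3000 nM to 20000 nM.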

Compound 4, half-maximal inhibitory concentration: > 5000 nM
Compound 4: no number, only a limit (the forecaster's own chance of this, stated with the estimate: 90%); the middle value is on the limit's open side.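

Among the compounds shown here, no step among compound 1, compound 2, compound 3 and compound 4 can be read in this assay, as all four give a limit of the assay and not a number: the limit of > 5000 nM in this assay, at which 4 of the 4 values shown sit. The compounds shown leave open how strongly any of them inhibits these cells, and whether any group at this place would give a measurable value.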